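Methoxy addition on two isomeric cores

The source may hold more compounds than are shown below. What is called first, only, known or untested is meant among the compounds shown, and "the series" means these compounds.

Measured compounds:
compound 1 `NS(=O)(=O)c1ccc(C/N=C/c2ccccc2OCc2cn(CCCOc3ccc4ccc(=O)oc4c3)nn2)cc1` — 14300 nM
compound 2 `NS(=O)(=O)c1ccc(C/N=C/c2ccc(OCc3cn(CCCOc4ccc5ccc(=O)oc5c4)nn3)cc2)cc1` — 125000 nM
compound 3 `COc1cccc(/C=N/Cc2ccc(S(N)(=O)=O)cc2)c1OCc1cn(CCCOc2ccc3ccc(=O)oc3c2)nn1` — 52500 nM

The series was read in a functional assay on HT-29 cells (Homo sapiens) for cytotoxicity, read by MTT assay, with a stated time of 24 h; on this read-out lower numbers stand for stronger inhibition and higher numbers for weaker inhibition. Compound 1 `NS(=O)(=O)c1ccc(C/N=C/c2ccccc2OCc2cn(CCCOc3ccc4ccc(=O)oc4c3)nn2)cc1` gives 14300 nM and is the lowest of the three numbers. Compound 2 `NS(=O)(=O)c1ccc(C/N=C/c2ccc(OCc3cn(CCCOc4ccc5ccc(=O)oc5c4)nn3)cc2)cc1` gives 125000 nM, the highest number of the three; the difference between the cores of compound 1 and compound 2 is not broken down here, the two having the same atoms joined differently. Compound 3 `COc1cccc(/C=N/Cc2ccc(S(N)(=O)=O)cc2)c1OCc1cn(CCCOc2ccc3ccc(=O)oc3c2)nn1` gives 52500 nM, between the other two.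

One change is seen once and is now repeated on the other core. From compound 1 to compound 3 the change is methoxy in place of hydrogen on an aromatic carbon and it gives a 3.7-fold higher number from compound 1 to compound 3 (0.56 log units; beyond the scatter). Compound 4 `COc1cc(/C=N/Cc2ccc(S(N)(=O)=O)cc2)ccc1OCc1cn(CCCOc2ccc3ccc(=O)oc3c2)nn1` is unmeasured; from compound 2 to compound 4 the change is methoxy in place of hydrogen on an aromatic carbon, the same kind of change at a place described in the same words. Nothing in the data shows whether the core of compound 2 answers this change as the core of compound 1 did.

For compound 4 a step of a 2.0-fold higher number from compound 2 to compound 4 (0.30 log units; within the scatter) in this assay is expected, resting on the step from compound 1 to compound 3 being a 3.7-fold higher number from compound 1 to compound 3 (0.56 log units; beyond the scatter) and on compound 2 already standing at 125000 nM. Compound 4 is estimated at 250000 nM, with a range of 80000 nM to 700000 nM; the assay may report only a limit here.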

Compound 4, half-maximal inhibitory concentration: 31600 nM
Beside the measured number, compound 4's estimate is 7.9-fold (0.90 log units) above it; the measured number lies below the stated range.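

Methoxy in place of hydrogen on an aromatic carbon gives a 4.0-fold lower number from compound 2 to compound 4 (0.60 log units; beyond the scatter) in this assay on the core of compound 2, so a step read on one of these two isomeric cores does not carry over to the other, even in direction. The two steps are close in size but opposite in sign, and the gap between them is larger than repeated measurements would explain: the same change on two cores in this assay, a 3.7-fold higher number (0.56 log units; beyond the scatter) from compound 1 to compound 3 and a 4.0-fold lower number (0.60 log units; beyond the scatter) from compound 2 to compound 4, 15-fold (1.16 log units) apart, beyond the scatter of two such steps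
This rests on a single pair per core in one cell assay, so it shows that the core matters to the outcome of this change, but not which structural difference between the cores sets the direction, and not that any rule holds beyond these four compounds.

Still open, going by these compounds, is whether the split belongs to methoxy itself or would also appear with hydroxy, ethoxy or chlorine on the same aromatic carbons. Also open, on these data alone, is whether a third arrangement of the same parts carrying methoxy would follow the core of compound 1, the core of compound 2, or neither.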